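A few compounds are considered here, and "the series" means these few. Any claim that something is new, unique, unknown or untested is made for them only; others in the source may bear on it.

Measured compounds:
compound 1, `CCCCCCCCCCCC[C@@H](O)[C@H]1CC[C@H]([C@H](O)CCCCCCCCCCNC(=O)c2cncs2)O1`: 100000 nM
compound 2, `CCCCCCCCCCCC[C@@H](O)[C@H]1CC[C@H]([C@H](O)CCCCCCCCCCNC(=O)c2ccsc2)O1`: 1700 nM
compound 3, `CCCCCCCCCCCC[C@@H](O)[C@H]1CC[C@H]([C@H](O)CCCCCCCCCCNC(=O)c2cccs2)O1`: 1820 nM

In a functional assay on St-4 cells (Homo sapiens) for inhibition, read by colorimetric assay and sulforhodamine B assay, with a stated time of 48 h (a lower number here means a stronger inhibitor of growth, a higher number a weaker inhibitor of growth), compound 3 stands second highest of the three numbers. Its nearest neighbour is compound 2, with a 1.1-fold higher number from compound 2 to compound 3 (0.03 log units; within the scatter); its furthest is compound 1, with a 55-fold lower number from compound 1 to compound 3 (1.74 log units; beyond the scatter). Compound 4, `CCCCCCCCCCCC[C@@H](O)[C@H]1CC[C@H]([C@H](O)CCCCCCCCCCNC(=O)c2ccoc2)O1`, differs from compound 3 by furan-3-yl in place of thiophen-2-yl on a carbonyl carbon. Of the measured steps, the one that bears most on this change is the exchange of one five-membered ring for another, a 1.1-fold higher number from compound 2 to compound 3 (0.03 log units; within the scatter), which stayed within the scatter, whereas the steps of a 59-fold lower number from compound 1 to compound 2 (1.77 log units; beyond the scatter) and a 55-fold lower number from compound 1 to compound 3 (1.74 log units; beyond the scatter) involved a ring with two hetero atoms and were large. Compound 4 is therefore expected to give 2500 nM (range 800 nM to 8000 nM), a step of a 1.4-fold higher number from compound 3 to compound 4 (0.14 log units; within the scatter) expected to lie within the scatter.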

Compound 4, concentration for 50% growth inhibition: 97700 nM
Compound 4: the middle estimate sits 39-fold (1.59 log units) below what was measured; the measured number lies above the stated range.
By their numbers in this assay, from the lowest: compounds 2 and 3 (each within the scatter of the next); then compounds 4 and 1 (each within the scatter of the next).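

In this assay the two rings with sulfur and the ring with oxygen do not behave alike, although each is a five-membered aromatic ring with 1 hetero atom: furan-3-yl gives a large rise from either thiophene (a 54-fold higher number from compound 3 to compound 4 (1.73 log units; beyond the scatter); a 57-fold higher number from compound 2 to compound 4 (1.76 log units; beyond the scatter)). Furan-3-yl cannot be told apart from 1,3-thiazol-5-yl (a 1.0-fold lower number from compound 1 to compound 4 (0.01 log units; within the scatter)), so among these compounds only the two thiophenes hold the lower numbers. Nothing measured here explains this difference. Still open, on these data alone, is whether furan-2-yl follows furan-3-yl or the thiophenes, and how a phenyl ring would fare on this carbonyl carbon.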